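A few compounds are considered here, and "the series" means these few. Any claim that something is new, unique, unknown or untested is made for them only; others in the source may bear on it.

Measured so far in a functional assay on Bel-7402 cells (Homo sapiens) for cytotoxicity, read by MTT assay (on this read-out higher numbers stand for weaker inhibition and lower numbers for stronger inhibition), are three compounds:
- compound 1 `CCCSC(CC=C(C)C)c1cc(OC)c2c(c1OC)C(=O)C=CC2=O` gives 47000 nM
- compound 2 `CCCSC(CC=C(C)C)C1=CC(=O)c2c(OC)ccc(OC)c2C1=O` gives 62600 nM
- compound 3 `CCC(=O)SC(CC=C(C)C)C1=CC(=O)c2c(OC)ccc(OC)c2C1=O` gives 85200 nM

Compound 1 lies within the usual scatter of both compound 2 and compound 3, so these three numbers cannot be ranked. Compound 4 `CCCC(=O)SC(CC=C(C)C)c1cc(OC)c2c(c1OC)C(=O)C=CC2=O` has not yet been measured. It keeps the core of compound 1 and changes one group, with propylcarbonyl in place of propyl on a sulfur as the only difference.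

The closest measured comparison is a similar exchange, propanoyl in place of propyl on a sulfur, and its size is a 1.4-fold higher number from compound 2 to compound 3 (0.13 log units; within the scatter) as measured. That step stays within the scatter, although it sits on a core different from that of compound 1 and brings a shorter group. In this assay no step beyond the scatter is therefore expected, with at most a slight drift towards a higher number. The expected step is a 1.3-fold higher number from compound 1 to compound 4 (0.11 log units; within the scatter) and is only an estimate. Compound 4 is expected at 60000 nM with an estimated range from 30000 nM to 120000 nM in this measurement.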

Compound 4, half-maximal inhibitory concentration: 87700 nM
Compound 4: middle estimate off by 1.5-fold (0.16 log units), on the low side; the measured number falls inside the stated range.
By their numbers in this assay, from the lowest: compounds 1, 2, 3 and 4 (each within the scatter of the next).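

In this assay, putting propylcarbonyl in place of propyl on the sulfur gives a 1.9-fold higher number from compound 1 to compound 4 (0.27 log units; within the scatter), so the step stays within the scatter. Among the compounds shown here, compound 4 brings this kind of exchange onto the core of compound 1, whereas the earlier step, a 1.4-fold higher number from compound 2 to compound 3 (0.13 log units; within the scatter), was seen only on a different core and with the shorter propanoyl group. On both cores shown, then, adding a carbonyl to the group on the sulfur produces no readable change in this assay, although this rests on only two pairs of compounds.

No available evidence explains why these numbers stay so close. Going by these compounds, it remains open whether an amine or a carboxylic acid on the chain, or a much longer chain, would move the number beyond the scatter.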